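A few compounds are considered here, and "the series" means these few. Any claim that something is new, unique, unknown or untested is made for them only; others in the source may bear on it.

Working notes on the series. Two compounds of the shared core have been run in a functional assay on WI-38 VA13 cells (Homo sapiens) for cytotoxicity; a lower number here means that less compound is needed, a higher number that more compound is needed for the effect. Compound 1, `CNc1c(C(=O)c2ccccc2)sc2nc(-c3cccs3)ccc12`, gives 0.42 ug/mL. Compound 2, `CCC(=O)c1sc2nc(-c3cccs3)ccc2c1N`, gives 0.89 ug/mL, the higher of the two numbers; the gap between compound 2 and compound 1 lies beyond the scatter of this assay, so compound 2 needs more material for the same effect.

The next compound is compound 3, `Nc1c(C(=O)c2ccc(F)c(F)c2)sc2nc(-c3cccs3)ccc12`. Relative to compound 2 the change is 3,4-difluorophenyl in place of ethyl on a carbonyl carbon. Compound 1 shows that an aryl ketone on this core sits at the lower end of the two numbers seen so far, which is the only basis for an expectation here. Compound 3 is therefore expected to move down from compound 2 by a 1.8-fold lower number from compound 2 to compound 3 (0.25 log units; within the scatter), toward the number of compound 1, while the step may still be close to the scatter. The estimate for compound 3 in this assay is 0.5 ug/mL, within 0.2 ug/mL to 1.2 ug/mL.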

Compound 3, half-maximal effective concentration: > 4 ug/mL
Compound 3: a limit, no number (the forecaster's own chance of this, stated with the estimate: 5%); middle value at least 8.0-fold (0.90 log units) from the limit.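

For the compounds shown here, this is the first step that can be read at a single position: 3,4-difluorophenyl in place of ethyl on a carbonyl carbon gives an at least 4.4-fold higher number from compound 2 to compound 3 (0.65 log units; beyond the scatter) in this assay. The group on this carbonyl carbon therefore matters, and on this pair the larger aromatic group goes with more compound being needed for the effect. The reading for compound 3 is a limit of the assay and not a number, so the step has a lower bound but no full size: the limit of > 4 ug/mL in this assay, at which 1 of the 3 values shown sits.

Compound 1 differs from compound 3 in more than one place, so the two cannot be compared as a single step. Still open, going by these compounds, is how a longer chain such as butyl, or an unsubstituted phenyl, on this carbonyl carbon would read with the free amine of compound 2 kept, which would separate the effect of the ring from that of its two fluorines.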